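The source may report more compounds than this note shows. Statements on the series, on what has been measured and on what is new or still open speak of the compounds shown alone.

Measured in an ADME assay on KB cells (Homo sapiens) for cytotoxicity, with a stated time of 48 h; a lower number here means a stronger inhibitor, a higher number a weaker inhibitor:
- compound 1 `C=C1[C@H](C)CCC[C@]1(C)CC/C(C)=C/CC1=C(O)C(=O)C=C(N[C@@H](C(=O)O)C(C)C)C1=O`: 6.2 ug/mL
- compound 2 `C=C1[C@H](C)CCC[C@]1(C)CC/C(C)=C/CC1=C(O)C(=O)C=C(N[C@@H](C(=O)O)[C@H](C)O)C1=O`: > 10 ug/mL, a limit
- compound 3 `CC1=CCC[C@](C)(CC/C(C)=C/CC2=C(O)C(=O)C=C(N[C@@H](CO)C(=O)O)C2=O)[C@@H]1C`: > 10 ug/mL, a limit

Compound 2 has no exact number in this assay: its entry of > 10 ug/mL is a limit of the assay. This position is not unique, as the series shows (the limit of > 10 ug/mL in this assay, at which 2 of the 3 values shown sit).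

The next compound is compound 4 `C=C1[C@H](C)CCC[C@]1(C)CC/C(C)=C/CC1=C(O)C(=O)C=C(NCC(=O)O)C1=O`, which has hydrogen in place of 1-hydroxyethyl on a saturated chain carbon bound to an amine nitrogen and a carbonyl carbon. The same difference, cut one bond further out, reads 1-carboxy-2-hydroxypropyl to carboxymethyl.

Within the data shown here, one measured step bears on this place: an at least 1.6-fold higher number from compound 1 to compound 2 (0.20 log units; that floor lies within the scatter), with 1-hydroxyethyl in place of isopropyl. Among the measured compounds shown here, its size is known only as a floor, and no measured compound carries hydrogen there. On these data alone, the direction of the coming change therefore stays open, and no change beyond the scatter is expected. The estimated step is a number no higher from compound 2 to compound 4 (the limit leaves the size open). A further reading as a limit is quite possible. Compound 4 is expected at 10 ug/mL, with an estimated range of 5 ug/mL to 20 ug/mL.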

Compound 4, half-maximal inhibitory concentration: 4 ug/mL
Beside the measured number, compound 4's estimate is 2.5-fold (0.40 log units) above it; measured number outside the range, below it.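

Hydrogen in place of 1-hydroxyethyl gives the first step at this place that clears the scatter: an at least 2.5-fold lower number from compound 2 to compound 4 (0.39 log units; beyond the scatter). Hydrogen and isopropyl, by contrast, are not separated at this place, since the step stays within the scatter: a 1.6-fold lower number from compound 1 to compound 4 (0.19 log units; within the scatter). Compound 2 reads > 10 ug/mL in this assay, which is a limit and not a number, so the step from it gives only a floor, and this reading is not alone in the series: the limit of > 10 ug/mL in this assay, at which 2 of the 4 values shown sit.

On these data alone, with no exact number for compound 2, the true size of its step to compound 4 stays open, and the series does not show whether the hydroxyl of 1-hydroxyethyl matters apart from the carbons that carry it, as compound 3 differs from the others in more than one place. Also open, as far as these compounds go, is how this saturated chain carbon bound to an amine nitrogen and a carbonyl carbon would read with a longer chain such as n-butyl, with a primary amine such as 4-aminobutyl, or with a carboxylic acid such as 2-carboxyethyl.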